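This account rests on a few compounds, and the source may have more. Where it says the series, first, only, none or still open, it means among the compounds named here.

Measured compounds:
Compound 1, `Nc1nn2c(O)cc(-c3ccc(F)cc3)nc2c1[N+](=O)[O-]`: > 100 ug/mL
Compound 2, `COc1ccc(NNCc2cc(O)n3nc(N)c([N+](=O)[O-])c3n2)cc1`: 66.3 ug/mL

In an ADME assay (Homo sapiens) for cytotoxicity (on this read-out higher numbers stand for lower toxicity in this test and lower numbers for higher toxicity in this test), compound 1 gives > 100 ug/mL, which is a limit of the assay and not a number. In this assay compound 2 gives 66.3 ug/mL. Compound 2 therefore holds the only number shown, the other value being (the limit of > 100 ug/mL in this assay, at which 1 of the 2 values shown sits). Among the measured compounds shown here, no step between measured compounds that differ in one place is available, so there is no measured precedent for the change to compound 3.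

Compound 3, `Nc1nn2c(O)cc(CNNC(N)S)nc2c1[N+](=O)[O-]`, differs from compound 2 by amino(sulfanyl)methyl in place of 4-methoxyphenyl on an amine nitrogen. The step from compound 2 to compound 3 is expected to be a 1.5-fold higher number from compound 2 to compound 3 (0.18 log units; within the scatter), a rise of moderate size toward lower toxicity, possibly reaching the limit of the assay. Compound 3 is accordingly estimated at 100 ug/mL, with a range from 50 ug/mL to 200 ug/mL.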

Compound 3, half-maximal cytotoxic concentration: > 50 ug/mL
Compound 3 ended at the assay's limit (the forecaster's own chance of this, stated with the estimate: 50%); the middle value does not contradict the limit.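

In this assay compound 3 gives > 50 ug/mL, which is a limit of the assay and not a number. Its steps from compound 2 and from compound 1 cannot be read. The compounds shown leave open how amino(sulfanyl)methyl compares with 4-methoxyphenyl on an amine nitrogen.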